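Halogen Swap on a Shared Core, Read for Cytotoxicity

The source may hold more compounds than are shown below. What is called first, only, known or untested is meant among the compounds shown, and "the series" means these compounds.

Three compounds share one core and differ only in the aryl group attached to a five-membered aromatic ring with 2 nitrogen and 1 oxygen. Compound 1 `COc1nc2ccccc2cc1/C=C/c1noc(-c2ccc(C)cc2)n1` carries a 4-methylphenyl there; in an ADME assay on HepG2 cells (Homo sapiens) for cytotoxicity, read by sulforhodamine B assay, with a stated time of 48 h (on this read-out higher numbers stand for lower toxicity in this test and lower numbers for higher toxicity in this test), compound 1 gives > 230000 nM, which is a limit of the assay rather than a number. Compound 2 `COc1ccccc1-c1nc(/C=C/c2cc3ccccc3nc2OC)no1` carries a 2-methoxyphenyl, and in this assay compound 2 gives > 220000 nM, again a limit. Compound 3 `COc1nc2ccccc2cc1/C=C/c1noc(-c2ccccc2Br)n1` carries a 2-bromophenyl, and in this assay compound 3 gives > 195000 nM, also a limit. With all three values sitting at limits, the steps among them cannot be read: a step that the two limits leave unreadable from compound 1 to compound 2, a step that the two limits leave unreadable from compound 1 to compound 3 and a step that the two limits leave unreadable from compound 2 to compound 3. Compound 3 thus stands at one of three limits, with no readable separation from the other two.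

Compound 4 `COc1nc2ccccc2cc1/C=C/c1noc(-c2cccc(Cl)c2)n1` differs from compound 3 in one place: 3-chlorophenyl in place of 2-bromophenyl on an aromatic carbon. Among the measured compounds shown here, the measured steps bear on this change only in that every aryl variation so far left the value at a limit, so no step beyond the scatter is readable in either direction. For compound 4 in this assay the expected value is 200000 nM, estimated to span 100000 nM to 400000 nM, with the step from compound 3 to compound 4 expected to be a step that the limit leaves unreadable from compound 3 to compound 4.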

Compound 4, half-maximal cytotoxic concentration: > 220000 nM
Compound 4: only a limit was reported (the forecaster's own chance of this, stated with the estimate: 80%); middle value at least 1.1-fold (0.04 log units) away from the limit.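

Compound 4, like compound 1, compound 2 and compound 3, gives only a limit in this assay and not a number, so none of the steps from those three compounds to compound 4 can be read. The compounds shown leave open what the actual values are, and whether changing the aryl group alters toxicity in this assay at all.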